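A few compounds are considered here, and "the series" means these few. Any claim that something is new, unique, unknown or untested is made for them only; others in the source may bear on it.

Measured in an assay on HL-60 cells for inhibition of glutathione S-transferase P (Homo sapiens), read by spectrophotometry, tested at 20 uM; a higher number here means more inhibition at the concentration tested (going by the name of the read-out), a lower number less inhibition:
compound 1, `Cc1ccc(/C=C2\CN(CC(=O)O)c3c(C)cccc3C2=O)cc1`, gives 46.8%
compound 2, `Cc1cc(C)cc(/C=C2\CN(CC(=O)O)c3c(C)cccc3C2=O)c1`, gives 17.5%
compound 3, `Cc1cccc2c1N(CC(=O)O)C/C(=C\c1ccccc1)C2=O`, gives 27.9%

Compound 3 stands second highest of the three numbers in this assay; compound 2 sits below it by a number 10.4 percentage points higher from compound 2 to compound 3 (beyond the scatter) and compound 1 above it by a number 18.9 percentage points lower from compound 1 to compound 3 (beyond the scatter), both steps beyond the scatter.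

Compound 4, `Cc1cccc2c1N(CC(=O)O)C/C(=C\c1ccccc1Cl)C2=O`, is not yet measured. It differs from compound 3 by chloro in place of hydrogen on an aromatic carbon, on the aryl ring carried by the double-bonded chain carbon. Among the compounds with values here, the steps that bear on it are those that alter this same ring: a number 29.3 percentage points lower from compound 1 to compound 2 (beyond the scatter) and a number 10.4 percentage points higher from compound 2 to compound 3 (beyond the scatter). Both are modest, and neither involves a chloro group, so they give the scale of what a change on this ring has done rather than its direction. The step of a number 18.9 percentage points lower from compound 1 to compound 3 (beyond the scatter) concerns the methyl on the core and does not bear on the present change. On this basis only a modest movement in this assay is expected, with direction uncertain; the estimated step from compound 3 is a number 2.1 percentage points higher from compound 3 to compound 4 (within the scatter). Compound 4 is therefore estimated at 30%, with a range of 14% to 48%.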

Compound 4, a percentage reported as inhibition, at one concentration (the size of the read-out at that concentration, not a potency): 51.9%
Estimate against measurement, compound 4: 21.9 percentage points below, and the stated range ends below it.
By their numbers in this assay, from the lowest: compound 2; then compound 3; then compounds 1 and 4 (each within the scatter of the next).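

In this assay, a single chloro on an aromatic carbon, ortho to a large group, gives a number 24 percentage points higher from compound 3 to compound 4 (beyond the scatter), so the number is higher with chloro than with hydrogen on the aryl ring carried by the double-bonded chain carbon. Set against the 3,5-dimethylphenyl of compound 2, the 2-chlorophenyl group gives a number 34.4 percentage points higher from compound 2 to compound 4 (beyond the scatter), while against the 4-methylphenyl of compound 1 it gives a number 5.1 percentage points higher from compound 1 to compound 4 (within the scatter), so these two singly substituted rings cannot be told apart in this assay. Nothing on hand accounts for the effect of the chloro group.

The compounds shown leave open whether the step belongs to chloro itself or to the place it occupies on the ring, a question that 2-methylphenyl, 2-fluorophenyl and 4-chlorophenyl analogues would help to separate. Also open, as far as these compounds go, is how a methoxy or an amine on this ring would read, and since every value is a reading at one concentration, the potency order of the series remains undefined.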